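A Side-Chain Swap at the Amide-Bearing Carbon

The source may report more compounds than this note shows. Statements on the series, on what has been measured and on what is new or still open speak of the compounds shown alone.

In a functional assay on the whole organism (Tail, strain ICR) with Mus musculus as the target, in the tail flick test, with a stated time of 150 min, at a dose of 25 umol/kg by the oral route (a higher number here means a stronger effect of the compound at the dose given, a lower number a weaker effect), the three measured compounds gave the following numbers:

compound 1, `O=C(O)[C@@H]1CCCN1C(=O)CN(c1nc(Cl)nc2[nH]cnc12)C1CC1`: 7.29%
compound 2, `C[C@@H](O)[C@H](NC(=O)CN(c1nc(Cl)nc2[nH]cnc12)C1CC1)C(=O)OCc1ccccc1`: 12.8%
compound 3, `C[C@@H](O)[C@H](NC(=O)CN(c1ncnc2c1ncn2C1CCCCO1)C1CC1)C(=O)OCc1ccccc1`: 6.53%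

Compound 3 stands lowest of these three numbers, yet its gap to compound 1 and its gap to compound 2 both lie within the scatter, so no order among the three can be read from them. Compound 4, `CC(C)C[C@H](NC(=O)CN(c1ncnc2c1ncn2C1CCCCO1)C1CC1)C(=O)OCc1ccccc1`, differs from compound 3 in one place: isobutyl in place of 1-hydroxyethyl on a saturated chain carbon bound to an amide-type nitrogen and a carbonyl carbon. Going by the values given here, no measured pair shows a step of this kind, so the direction of the change is unknown. Given that every number so far sits low and close together, the step in this assay from compound 3 to compound 4 is expected to be a number 1.5 percentage points higher from compound 3 to compound 4 (within the scatter), not beyond the scatter. Compound 4 is estimated at 8%, within a range from 0% to 20%.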

Compound 4, a percentage reported as activity, at one dose (the size of the read-out at that dose, not a potency): 6.47%
The estimate for compound 4 lay 1.5 percentage points above the measured number; the range from low to high includes it.
By their numbers in this assay, from the lowest: compounds 4, 3, 1 and 2 (each within the scatter of the next).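

In this assay, the first single-place step among these compounds is a number 0.1 percentage points lower from compound 3 to compound 4 (within the scatter). At this saturated chain carbon bound to an amide-type nitrogen and a carbonyl carbon, 1-hydroxyethyl, with its hydrogen-bond donor and acceptor, gives way to isobutyl without a step beyond the scatter. Nothing available explains this result. As far as these compounds go, whether an amine or a carboxylic acid on this carbon would give a step beyond the scatter stays open. So does whether the same swap would read alike on the core of compound 2.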